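The source may report more compounds than this note shows. Statements on the series, on what has been measured and on what is new or still open speak of the compounds shown alone.

In a functional assay on MT2 cells (Homo sapiens) for cytotoxicity (a lower number here means that less compound is tolerated, a higher number that more compound is tolerated), compound 1 (`CCCc1ccc(Nc2nccs2)cc1OCC=C(C)C`) gives 23000 nM while compound 2 (`CCc1ccc(Nc2nccs2)cc1OCC=C(C)C`) gives 31000 nM and compound 3 (`COc1ccc(Nc2nccs2)cc1OCC=C(C)C`) gives 42000 nM in the same read-out. Compound 3 therefore stands within the scatter of both others. Compound 4 (`CC(C)=CCOc1cc(Nc2nccs2)ccc1Cl`) has chloro in place of methoxy on an aromatic carbon, ortho to a (3-methylbut-2-en-1-yl)oxy group and para to a (1,3-thiazol-2-yl)amino group (chloro in place of methoxy on an aromatic carbon). Two measured steps change the group at this place: a 1.8-fold higher number from compound 1 to compound 3 (0.26 log units; within the scatter) and a 1.4-fold higher number from compound 2 to compound 3 (0.13 log units; within the scatter) both stay within the scatter. The step of a 1.3-fold higher number from compound 1 to compound 2 (0.13 log units; within the scatter) also stays within it. Going by the values given here, no chloro compound has been measured, so no step beyond the scatter is expected in this assay on this evidence. The estimated change is a 1.4-fold lower number from compound 3 to compound 4 (0.15 log units; within the scatter) and remains within the scatter. Compound 4 is estimated at 30000 nM with an expected range from 15000 nM to 55000 nM in this read-out.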

Compound 4, half-maximal cytotoxic concentration: 26000 nM
Beside the measured number, compound 4's estimate is 1.2-fold (0.06 log units) above it, within the range that was stated.
By their numbers in this assay, from the lowest: compounds 1, 4, 2 and 3 (each within the scatter of the next).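

In this assay chloro on this aromatic carbon, with one heavy atom and no hydrogen-bond acceptor, stays within the scatter of methoxy (a 1.6-fold lower number from compound 3 to compound 4 (0.21 log units; within the scatter)), ethyl (a 1.2-fold lower number from compound 2 to compound 4 (0.08 log units; within the scatter)) and propyl (a 1.1-fold higher number from compound 1 to compound 4 (0.05 log units; within the scatter)). These four groups at this place therefore cannot be told apart in this read-out. Nothing available offers an explanation for this flat result. Still open, going by these compounds, is whether an amine, a carboxylic acid or a longer chain here would step beyond the scatter. Also open, on these data alone, is whether replacing the (3-methylbut-2-en-1-yl)oxy group would do so.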